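Amide-end variation: from compound 2 to compound 3

A few compounds are considered here, and "the series" means these few. Any claim that something is new, unique, unknown or untested is made for them only; others in the source may bear on it.

Measured so far:
compound 1 `CCOC(=O)C1CCN(C(=O)CN2CN(c3ccccc3)C3(CCN(C(=O)c4ccc(C5CCCCC5)cc4)CC3)C2=O)CC1`: 900 nM
compound 2 `CC(C)(C)OC(=O)NCCNC(=O)CN1CN(c2ccccc2)C2(CCN(C(=O)c3ccc(C4CCCCC4)cc3)CC2)C1=O`: 5500 nM

In an assay on HEK293 cells for displacement of a labelled ligand from NPC1-like intracellular cholesterol transporter 1 (Homo sapiens) (a lower number here means a stronger inhibitor, a higher number a weaker inhibitor), compound 2 gives 5500 nM, the higher of the two numbers; compound 1 gives 900 nM. Compound 3 `CCC1CCCN(C(=O)CN2CN(c3ccccc3)C3(CCN(C(=O)c4ccc(C5CCCCC5)cc4)CC3)C2=O)C1` differs from compound 2 as follows: 3-ethylpiperidin-1-yl in place of (2-((tert-butoxycarbonyl)amino)ethyl)amino on a carbonyl carbon. Going by the values given here, the one measured step that bears on this change is a 6.1-fold higher number from compound 1 to compound 2 (0.79 log units; beyond the scatter), in which the 4-(ethoxycarbonyl)piperidin-1-yl amide was exchanged for the open-chain (2-((tert-butoxycarbonyl)amino)ethyl)amino amide. Compound 3 goes back to a piperidin-1-yl amide, this time carrying an ethyl group and no ester, so a lowering of roughly the size seen in that step is expected, landing near compound 1. Compound 3 is therefore estimated at 1200 nM, with a range of 400 nM to 4000 nM, which is an expected step of a 4.6-fold lower number from compound 2 to compound 3 (0.66 log units; beyond the scatter); the ester is absent, so the match to compound 1 is uncertain.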

Compound 3, half-maximal inhibitory concentration: 2600 nM
Estimate against measurement, compound 3: 2.2-fold (0.34 log units) below; the range from low to high includes it.
By their numbers in this assay, from the lowest: compound 1; then compound 3; then compound 2.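

In this assay, returning to a piperidin-1-yl amide does not by itself restore the level of compound 1: the exchange of the open-chain (2-((tert-butoxycarbonyl)amino)ethyl)amino group for 3-ethylpiperidin-1-yl gives a 2.1-fold lower number from compound 2 to compound 3 (0.33 log units; beyond the scatter) and remains modest. The two ring amides are also separated, with a 2.9-fold higher number from compound 1 to compound 3 (0.46 log units; beyond the scatter) showing that the substituents on the piperidine ring matter at this carbonyl carbon. No available evidence explains either difference.

The 1>3 change moves the substituent and replaces ethoxycarbonyl with ethyl at once, so the contribution of each remains unresolved. Unsubstituted piperidin-1-yl, 4-ethylpiperidin-1-yl and 3-(ethoxycarbonyl)piperidin-1-yl would separate these two changes, while a 4-carboxylic acid on the piperidine ring would test the ester itself.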